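A Furan for a Pyridazine at the Alkyne Terminus

A few compounds are considered here, and "the series" means these few. Any claim that something is new, unique, unknown or untested is made for them only; others in the source may bear on it.

Measured so far in an assay on CHO cells for displacement of a labelled ligand from adenosine receptor A3 (Homo sapiens), read by scintillation counting, with a stated time of 60 min; a lower number here means a stronger inhibitor, a higher number a weaker inhibitor:
Compound 1, `CNC(=O)[C@@]12C[C@@H]1[C@@H](n1cnc3c(NC)nc(C#Cc4ccc(CO)cc4)nc31)[C@H](O)[C@@H]2O`: 2.16 nM
Compound 2, `CNC(=O)[C@@]12C[C@@H]1[C@@H](n1cnc3c(NC)nc(C#Cc4cccnn4)nc31)[C@H](O)[C@@H]2O`: 3.53 nM

Compound 2 stands alongside compound 1 on these numbers: the two values lie within the scatter of each other, so neither can be set apart in this assay. Among the compounds with values here, the one step seen so far, a 1.6-fold higher number from compound 1 to compound 2 (0.21 log units; within the scatter), comes from placing a pyridazin-3-yl in place of a 4-(hydroxymethyl)phenyl on the triple-bonded carbon, and it stayed within the scatter.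

Compound 3, `CCc1ccc(C#Cc2nc(NC)c3ncn([C@H]4[C@H](O)[C@H](O)[C@]5(C(=O)NC)C[C@H]45)c3n2)o1`, carries a further exchange at that same carbon: 5-ethylfuran-2-yl in place of pyridazin-3-yl on a triple-bonded carbon. Within the data shown here, the only measured step that bears on this change is a 1.6-fold higher number from compound 1 to compound 2 (0.21 log units; within the scatter), and it was small. With a single comparison pointing to tolerance at this position, the expectation is that the new ring will again give no movement beyond the scatter in this assay. Compound 3 is therefore estimated at 3.5 nM, with a range from 1.2 nM to 10 nM. The expected step is a 1.0-fold lower number from compound 2 to compound 3 (0.00 log units; within the scatter).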

Compound 3, inhibition constant: 1.5 nM
Compound 3: the middle estimate sits 2.3-fold (0.37 log units) above what was measured; measured number inside the range.
By their numbers in this assay, from the lowest: compounds 3, 1 and 2 (each within the scatter of the next, the first and the last beyond it).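

In this assay, this position now shows its first step beyond the scatter: a 2.4-fold lower number from compound 2 to compound 3 (0.37 log units; beyond the scatter), a modest move on exchanging pyridazin-3-yl, a six-membered aromatic ring with 2 hetero atoms, for 5-ethylfuran-2-yl, a five-membered aromatic ring with 1 hetero atom. Within the data shown here, the triple-bonded carbon therefore does not accept every ring alike, yet the other comparison, a 1.4-fold lower number from compound 1 to compound 3 (0.16 log units; within the scatter), stays within the scatter, so 5-ethylfuran-2-yl and 4-(hydroxymethyl)phenyl cannot be set apart, and the first and last compounds in the order differ only through the pair of compound 2 and compound 3. Nothing available explains why the two rings in that pair differ in this way.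

The compounds shown leave open whether the step belongs to the furan ring itself or to its ethyl group, which an unsubstituted furan-2-yl or a longer chain such as propyl on the same ring would help to separate. They also leave open how an amine or a carboxylic acid on that ring would read in this assay, since the groups at this carbon so far carry only a hydroxymethyl or an ethyl substituent, or none.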